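A Fluoro Step Repeated on a Second Ester Core

The compounds below may be only part of what the source reports. "The series", "measured", "known", "first", "only" and "open" are said of these compounds alone.

Compound 1, `CCCCOC(=O)c1cc(N2C(=O)C3=C(CCCC3)C2=O)ccc1Cl`, gives 6310 nM in a functional assay on the whole organism for inhibition, with Scenedesmus acutus as the target; a higher number here means a weaker inhibitor, a lower number a stronger inhibitor.
Compound 2, `CCCCOC(=O)c1cc(N2C(=O)C3=C(CCCC3)C2=O)c(F)cc1Cl`, gives 126 nM in this assay.
Compound 3, `CCC(C)OC(=O)c1cc(N2C(=O)C3=C(CCCC3)C2=O)ccc1Cl`, gives 1100 nM in this assay.

Two single changes connect these three. The first is fluoro in place of hydrogen on an aromatic carbon, and it brought a 50-fold lower number from compound 1 to compound 2 (1.70 log units; beyond the scatter). The second is sec-butyl in place of butyl on an oxygen next to a carbonyl group, which brought a 5.7-fold lower number from compound 1 to compound 3 (0.76 log units; beyond the scatter).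

Compound 4, `CCC(C)OC(=O)c1cc(N2C(=O)C3=C(CCCC3)C2=O)c(F)cc1Cl`, has not yet been measured. It differs from compound 3 by fluoro in place of hydrogen on an aromatic carbon. Among the compounds with values here, this is the same kind of change as the one from compound 1 to compound 2, not the same one: in that pair the fluoro sits para to a butoxycarbonyl group, here it sits para to a sec-butoxycarbonyl group, the two cores differing by sec-butyl in place of butyl on an oxygen next to a carbonyl group.

The expectation for compound 4 rests on a single precedent, the step of a 50-fold lower number from compound 1 to compound 2 (1.70 log units; beyond the scatter), and a step of about a 44-fold lower number from compound 3 to compound 4 (1.64 log units; beyond the scatter) is expected here. Compound 4 is therefore estimated at 25 nM in this assay, most likely between 6 nM and 110 nM.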

Compound 4, half-maximal inhibitory concentration: 60.3 nM
Compound 4: the middle estimate sits 2.4-fold (0.38 log units) below what was measured; the measured number falls inside the stated range.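

In this assay, fluoro in place of hydrogen on an aromatic carbon again lowered the number, with an 18-fold lower number from compound 3 to compound 4 (1.26 log units; beyond the scatter), but the size of the step did not carry over intact: the same change on two cores in this assay, a 50-fold lower number (1.70 log units; beyond the scatter) from compound 1 to compound 2 and an 18-fold lower number (1.26 log units; beyond the scatter) from compound 3 to compound 4, 2.7-fold (0.44 log units) apart, beyond the scatter of two such steps
Read the other way round, sec-butyl in place of butyl also kept its direction on the fluorinated core, with a 2.1-fold lower number from compound 2 to compound 4 (0.32 log units; beyond the scatter), and it too came out smaller than on the core of compound 1: the same change on two cores in this assay, a 5.7-fold lower number (0.76 log units; beyond the scatter) from compound 1 to compound 3 and a 2.1-fold lower number (0.32 log units; beyond the scatter) from compound 2 to compound 4, 2.7-fold (0.44 log units) apart, beyond the scatter of two such steps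
Across these four compounds, then, the direction of each change carried from one core to the other while its size did not, though a single pair of steps for each change cannot show what sets the gap or whether the direction would hold on any further core.

The compounds shown leave open whether the fluoro step keeps its direction with a longer chain on the ester oxygen, or with a carboxylic acid in place of the ester. They also leave open whether bromo in place of the fluoro would give a step of similar size.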